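Removing the propyl from the ring nitrogen

The compounds below may be only part of what the source reports. "The series", "measured", "known", "first", "only" and "open" are said of these compounds alone.

Compound 2 `CCCn1cnc2cc3c(cc21)C1CNCC3C1` and compound 1 `Cc1nc2cc3c(cc2[nH]1)C1CNCC3C1` share the same fused tetracyclic core and differ only in the decoration of the five-membered aromatic ring. In an assay on HEK293 cells for binding affinity to Neuronal acetylcholine receptor; alpha4/beta2 (Homo sapiens) (a lower number here means a stronger inhibitor, a higher number a weaker inhibitor), compound 1 gives 0.1 nM, whereas compound 2 gives 0.36 nM. Compound 2 thus holds the highest of the two numbers, and its nearest neighbour, compound 1, sits at a clearly lower number, a gap beyond the usual scatter of this assay. Compound 3 `c1nc2cc3c(cc2[nH]1)C1CNCC3C1` is the next member of the series: hydrogen in place of propyl on an aromatic nitrogen, that is, a hydrogen in place of the propyl on the aromatic nitrogen. For the measured compounds named here, no measured pair in this set isolates that exact change, so the expectation must lean on compound 1, whose value of 0.1 nM shows that a core without the propyl can reach a very low number in this assay. Compound 3 is therefore expected to give about 0.15 nM, within a range of 0.05 nM to 0.5 nM. That estimate corresponds to a step of a 2.4-fold lower number from compound 2 to compound 3 (0.38 log units; beyond the scatter), expected to run toward a lower number and to lie somewhat beyond the scatter.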

Compound 3, inhibition constant: 0.15 nM
Compound 3: the middle estimate sits on the measured number at the digits printed, and the stated range covers the measured number.
By their numbers in this assay, from the lowest: compounds 1 and 3 (each within the scatter of the next); then compound 2.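

Taking the propyl off the aromatic nitrogen gives a 2.4-fold lower number from compound 2 to compound 3 (0.38 log units; beyond the scatter) in this assay, the first reading in this set of a change at that nitrogen alone. It shows that a low number does not depend on an alkyl group there, since the compound with hydrogen at this position reads lower than the propyl compound, although the step is modest. For the compounds shown here, compound 1 and compound 3 differ at the aromatic carbon instead, and hydrogen in place of methyl there gives a 1.5-fold higher number from compound 1 to compound 3 (0.18 log units; within the scatter), so of these two single changes only the one on the nitrogen lies beyond the scatter.

Propyl is the only chain shown on that nitrogen, so the compounds leave open whether a shorter methyl or ethyl group, a longer butyl chain or a hydroxyethyl group would follow the same direction, and how an amine or a carboxylic acid on the aromatic carbon would read. Nothing here explains why the propyl compound gives the higher number, as no supporting evidence is available on that point.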